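Chloro series: methyl on the amide-type nitrogen

The compounds below may be only part of what the source reports. "The series", "measured", "known", "first", "only" and "open" are said of these compounds alone.

In a functional assay on thoracic aorta (Rattus norvegicus, strain Wistar), with a stated time of 15 min (on this read-out higher numbers stand for an effect only at larger amounts of compound and lower numbers for an effect already at smaller amounts), compound 3 (`CCOc1ccc(F)cc1C(C)NC(=O)NS(=O)(=O)c1ccc(Cl)cc1`) gives > 300000 nM, which is a limit and not a number. Compound 1 (`CCOc1ccc(F)cc1C(C)NC(=O)NS(=O)(=O)c1ccc(C)cc1`) gives > 300000 nM, also a limit. Compound 3 therefore stands at the limit of > 300000 nM in this assay, at which 2 of the 3 values shown sit. Chloro in place of methyl on an aromatic carbon is a step that the two limits leave unreadable from compound 1 to compound 3, so the numbers do not separate these two compounds.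

Compound 4 (`CCOc1ccc(F)cc1C(C)NC(=O)N(C)S(=O)(=O)c1ccc(Cl)cc1`) carries methyl in place of hydrogen on an amide-type nitrogen whose other neighbours are the carbonyl carbon and the sulfonyl sulfur (methyl in place of hydrogen on an amide-type nitrogen).

Compound 2 (`CCOc1ccc(F)cc1C(C)NC(=O)N(C)S(=O)(=O)c1ccc(C)cc1`) gives 7800 nM in this assay. It is the only measured case of this change, which appears as an at least 38-fold lower number from compound 1 to compound 2 (1.58 log units; beyond the scatter). As far as these compounds go, that step is large and beyond the scatter, and its true size remains open since it starts from a limit. From the compounds shown here alone, the other measured step cannot be read, so how chloro behaves once the nitrogen carries methyl is unknown.

Going by the values given here, on the single precedent of an at least 38-fold lower number from compound 1 to compound 2 (1.58 log units; beyond the scatter), a large step towards a lower number is expected in this assay. The estimated step is an at least 50-fold lower number from compound 3 to compound 4 (1.69 log units; beyond the scatter). Compound 4 is expected at 6000 nM, with an estimated range of 1500 nM to 25000 nM.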

Compound 4, half-maximal effective concentration: 24500 nM
Compound 4: middle estimate off by 4.1-fold (0.61 log units), on the low side, and the stated range covers the measured number.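

In this assay, methyl in place of hydrogen on the amide-type nitrogen now also gives a measurable number on the chloro core, with an at least 12-fold lower number from compound 3 to compound 4 (1.08 log units; beyond the scatter), so the change no longer rests on a single core: the same change on two cores in this assay, an at least 38-fold lower number (1.58 log units; beyond the scatter) from compound 1 to compound 2 and an at least 12-fold lower number (1.08 log units; beyond the scatter) from compound 3 to compound 4; the limit leaves it open whether they differ

With methyl on that nitrogen in both compounds, the two aromatic substituents can now be told apart, and chloro in place of methyl on an aromatic carbon appears as a 3.1-fold higher number from compound 2 to compound 4 (0.50 log units; beyond the scatter), a modest step but one beyond the scatter. The matching step with the amide hydrogen in place cannot be read, since compound 1 and compound 3 both stand at a limit and not at a number: the limit of > 300000 nM in this assay, at which 2 of the 4 values shown sit.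

Still open, as far as these compounds go, is how far the methyl step really reaches on each core, and whether the chloro-to-methyl gap seen with methyl on the nitrogen holds for other groups at that nitrogen. An ethyl group or a longer chain on the same nitrogen, or a methoxy group on the aromatic carbon that carries chloro or methyl here, would test whether the trend extends beyond these four compounds.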